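Moving a branch on the sulfur chain of a pyrimidinone core

A few compounds are considered here, and "the series" means these few. Any claim that something is new, unique, unknown or untested is made for them only; others in the source may bear on it.

Three compounds share a core and were tested in an ADME assay on MT4 cells (Homo sapiens) for activation, read by MTT assay; on this read-out lower numbers stand for higher toxicity in this test and higher numbers for lower toxicity in this test. Compound 1 `Cc1c(C(C)c2c(F)cccc2Cl)nc(SC(C)C)[nH]c1=O` gives > 15000 nM, a limit of the assay rather than a number. Compound 2 `CCCSc1nc(C(C)c2c(F)cccc2Cl)c(C)c(=O)[nH]1` gives > 1500 nM, also a limit. Compound 3 `CCC(c1nc(SC(C)C)[nH]c(=O)c1C)c1c(F)cccc1Cl` gives > 3000 nM, again a limit. Compound 2 arises from compound 1 through (propyl in place of isopropyl on a sulfur), and because both values are limits the step that the two limits leave unreadable from compound 1 to compound 2 cannot be read. Compound 3 differs from compound 1 by methyl in place of hydrogen on a saturated chain carbon, two bonds along the chain from two aromatic carbons. Compound 4 `CCCSc1nc(C(CC)c2c(F)cccc2Cl)c(C)c(=O)[nH]1`, not yet measured, arises from compound 3 through (propyl in place of isopropyl on a sulfur), the same change as from compound 1 to compound 2, at the same place. Since that earlier step is unreadable, compound 4 is expected to stay near its parent, with a step that the limit leaves unreadable from compound 3 to compound 4. Compound 4 is thus estimated at 10000 nM.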

Compound 4, half-maximal cytotoxic concentration: > 3000 nM
Compound 4 gave a limit, no number; the forecaster's own chance of this, stated with the estimate: 75%; the middle value does not contradict the limit.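

Compound 4 gives only a limit, as do compound 2 and compound 3, so neither step leading to compound 4 can be read. The compounds shown leave open where any of the four actually becomes toxic, and whether either change matters.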